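Bromo for chloro on the aryl ring: lipophilicity notes

The compounds below may be only part of what the source reports. "The series", "measured", "known", "first", "only" and "open" are said of these compounds alone.

Compound 1 `CC(=N)Nc1cccc(C(=O)NNC(=O)CC(CC(=O)O)c2ccc(Cl)cc2)c1` and compound 2 `CC(=N)Nc1cccc(C(=O)NNC(=O)CC(CC(=O)O)c2ccc(Br)cc2)c1` share one core; compound 2 differs from compound 1 by bromo in place of chloro on an aromatic carbon. In a physicochemical assay for lipophilicity (on this read-out lower numbers stand for lower lipophilicity and higher numbers for higher lipophilicity), compound 1 gives 2 and compound 2 gives 2.27; the step is a number 0.27 log units higher from compound 1 to compound 2 (within the scatter), so the two cannot be ordered against each other on this read-out.

Compound 3 `O=C(O)CC(CC(=O)NNC(=O)CCCCNc1ccccn1)c1ccc(Cl)cc1` carries a different core; how the two cores differ is not broken down here. In this assay compound 3 gives 2.63, the highest of the three numbers, lying beyond the scatter from both compound 2 and compound 1.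

Compound 4 `O=C(O)CC(CC(=O)NNC(=O)CCCCNc1ccccn1)c1ccc(Br)cc1` differs from compound 3 by bromo in place of chloro on an aromatic carbon, the same change as between compound 1 and compound 2, at a place described in the same words. In this assay a step of a number 0.27 log units higher from compound 3 to compound 4 (within the scatter) is expected, because the matching earlier step was a number 0.27 log units higher from compound 1 to compound 2 (within the scatter). Compound 4 is therefore estimated at 2.9, with 2.6 to 3.2 as the expected range.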

Compound 4, partition coefficient: 2.9
For compound 4 middle estimate and measured number coincide at the digits printed, and the stated range covers the measured number.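

In this assay the new step reads a number 0.27 log units higher from compound 3 to compound 4 (within the scatter), printed at the same size as the earlier a number 0.27 log units higher from compound 1 to compound 2 (within the scatter), so 4-chlorophenyl to 4-bromophenyl gives matching steps in the two cores shown. This supports carrying the step over as a working estimate between these two cores, but it does not establish a real difference within either pair: both steps lie within the scatter, so compound 3 and compound 4 cannot be ordered against each other, any more than compound 1 and compound 2, and two pairs make no general rule for the series. Nothing measured here accounts for the match between the two steps.

Open, going by these compounds, is how fluoro, iodo or methoxy on the same aromatic carbon would read in this assay alongside chloro and bromo. Also open, on these data alone, is whether the step would carry over to a core in which an ester or a tetrazole stands in place of the carboxylic acid.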